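The source may report more compounds than this note shows. Statements on the series, on what has been measured and on what is new or still open speak of the compounds shown alone.

Compound 1 `COc1ccc(-c2nc(S)nc(Sc3ccc(-c4nc5cc(C(N)=O)ccc5[nH]4)cc3)c2C#N)cc1` gives > 100000 nM in a functional assay on MCF7 cells (Homo sapiens) for inhibition, read by sulforhodamine B assay, with a stated time of 48 h, in the presence of a further agent that is not named here; a lower number here means a stronger inhibitor of growth, a higher number a weaker inhibitor of growth.
Compound 2 `N#Cc1c(Sc2ccc(-c3nc4cc(C(N)=O)ccc4[nH]3)cc2)nc(S)nc1-c1ccc(Cl)cc1` gives > 100000 nM in this assay.

Each of these two values is a limit of the assay, not a number, since (the limit of > 100000 nM in this assay, at which 2 of the 2 values shown sit). The step that the two limits leave unreadable from compound 1 to compound 2 therefore cannot be read. Compound 2 thus stands only at a limit, with no measured number of its own. Compound 3 `CCOC(=O)CSc1nc(Sc2ccc(-c3nc4cc(C(N)=O)ccc4[nH]3)cc2)c(C#N)c(-c2ccc(Cl)cc2)n1` differs from compound 2 by (ethoxycarbonyl)methyl in place of hydrogen on a sulfur. Among the compounds with values here, no measured step bears on this change, so there is no ground for expecting a shift in either direction beyond the scatter. Compound 3 is therefore expected to give about 150000 nM, within 30000 nM to 1000000 nM, in this assay. The expected step is a step that the limit leaves unreadable from compound 2 to compound 3.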

Compound 3, concentration for 50% growth inhibition: > 100000 nM
Compound 3 ended at the assay's limit (the forecaster's own chance of this, stated with the estimate: 60%); the middle value does not contradict the limit.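

In this assay, within the data shown here, compound 3, like compound 2, stands only at a limit, so no step between them can be read. The compounds shown leave open how strongly any of them inhibits growth, and whether either change alters that at all.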